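Adding 4-Methylpiperazin-1-yl to Compound 3

The source may report more compounds than this note shows. Statements on the series, on what has been measured and on what is new or still open speak of the compounds shown alone.

Of the compounds shown here, three sharing one core have been tested in a functional assay on MDA-MB-231 cells (Homo sapiens) for cytotoxicity, read by MTT assay, with a stated time of 72 h; on this read-out higher numbers stand for weaker inhibition and lower numbers for stronger inhibition. Compound 1 `CN1CCN(c2ccc(NC(=N)c3cc4cn[nH]c4cn3)cc2)CC1` gives 47500 nM, compound 2 `CN1CCN(c2ccc(NC(=N)c3cc4c(-c5ccccc5)n[nH]c4c(NC4CCCCC4)n3)cc2)CC1` gives 1500 nM, and compound 3 `N=C(Nc1ccccc1)c1cc2c(-c3ccccc3)n[nH]c2cn1` gives 11000 nM. Compound 3 thus stands second highest of the three numbers, below compound 1 but well above compound 2, both gaps lying beyond the scatter. Compound 4 `CN1CCN(c2ccc(NC(=N)c3cc4c(-c5ccccc5)n[nH]c4cn3)cc2)CC1` differs from compound 3 in one place: 4-methylpiperazin-1-yl in place of hydrogen on an aromatic carbon. Within the data shown here, compounds 1 and 2 both carry this group, yet each also differs from compound 3 elsewhere, so no single measured step isolates the change. A modest fall in the number is expected, the step being estimated at a 2.2-fold lower number from compound 3 to compound 4 (0.34 log units; beyond the scatter). Compound 4 is therefore expected to give about 5000 nM, within a range from 1500 nM to 15000 nM.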

Compound 4, half-maximal inhibitory concentration: 15900 nM
The estimate for compound 4 lay 3.2-fold (0.50 log units) below the measured number; the whole stated range lies below it.
By their numbers in this assay, from the lowest: compound 2; then compounds 3 and 4 (each within the scatter of the next); then compound 1.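

In this assay, 4-methylpiperazin-1-yl in place of hydrogen on this aromatic carbon makes no clear difference, with a 1.4-fold higher number from compound 3 to compound 4 (0.16 log units; within the scatter), while changes elsewhere on the shared core show up more clearly: hydrogen in place of cyclohexylamino gives an 11-fold higher number from compound 2 to compound 4 (1.03 log units; beyond the scatter), and phenyl in place of hydrogen gives a 3.0-fold lower number from compound 1 to compound 4 (0.48 log units; beyond the scatter). Nothing available explains these steps. Going by these compounds, it remains open whether a piperazine without its methyl, or a simple amine on the same carbon, would also stay within the scatter, and whether 4-methylpiperazin-1-yl matters more when cyclohexylamino is present.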